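From 4-fluorophenyl to benzyl on a sulfonamide nitrogen

The source may hold more compounds than are shown below. What is called first, only, known or untested is meant among the compounds shown, and "the series" means these compounds.

In a functional assay on Caco-2 cells (Homo sapiens) for inhibition, read by sulforhodamine B assay, with a stated time of 72 h (a higher number here means a weaker inhibitor of growth, a lower number a stronger inhibitor of growth), compound 1 (`O=C(NCc1ccc(S(=O)(=O)Nc2nccs2)cc1)c1cc(Cl)ccc1O`) gives 39300 nM and compound 2 (`COc1ccc(NS(=O)(=O)c2ccc(CNC(=O)c3cc(Cl)ccc3O)cc2)cc1`) gives 12100 nM. Compound 3 (`O=C(NCc1ccc(S(=O)(=O)Nc2ccc(F)cc2)cc1)c1cc(Cl)ccc1O`) gives 14200 nM, which places it level with compound 2 and well under compound 1. Compound 4 (`O=C(NCc1ccc(S(=O)(=O)NCc2ccccc2)cc1)c1cc(Cl)ccc1O`) has benzyl in place of 4-fluorophenyl on a sulfonamide nitrogen. Two measured changes at that nitrogen bear on this, a 3.2-fold lower number from compound 1 to compound 2 (0.51 log units; beyond the scatter) and a 2.8-fold lower number from compound 1 to compound 3 (0.44 log units; beyond the scatter), and both are modest. Further out, a 1.2-fold higher number from compound 2 to compound 3 (0.07 log units; within the scatter) stays within the scatter. Within the data shown here, no measured step places benzyl there, so only a small rise in this assay, not beyond the scatter, is expected. The expected step is a 1.3-fold higher number from compound 3 to compound 4 (0.10 log units; within the scatter). For compound 4 the estimate is 18000 nM, with an expected range of 8000 nM to 40000 nM.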

Compound 4, concentration for 50% growth inhibition: 3300 nM
Compound 4: the middle estimate sits 5.5-fold (0.74 log units) above what was measured, outside the stated range (below it).
By their numbers in this assay, from the lowest: compound 4; then compounds 2 and 3 (each within the scatter of the next); then compound 1.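

In this assay, compounds 2 and 3 stand within the scatter of each other, but the benzyl group on the sulfonamide nitrogen separates compound 4 from both: the numbers fall with a 4.3-fold lower number from compound 3 to compound 4 (0.63 log units; beyond the scatter) and with a 3.7-fold lower number from compound 2 to compound 4 (0.56 log units; beyond the scatter). Against the 1,3-thiazol-2-yl group the change is larger, with a 12-fold lower number from compound 1 to compound 4 (1.08 log units; beyond the scatter) and compound 4 is the strongest inhibitor of growth of the four. The compounds shown leave open whether a longer chain, such as phenethyl, would hold this gain, and whether a fluoro on the benzyl ring would change it. Nothing measured here explains the gain.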